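The source may report more compounds than this note shows. Statements on the series, on what has been measured and on what is new or still open speak of the compounds shown alone.

For the measured compounds named here, in a functional assay on the whole organism (strain albino) for inhibition, with Rattus norvegicus as the target, read by paw edema, with stated times of 30 min and 3 h, at a dose of 0.28 mmol/kg by the oral route (on this read-out higher numbers stand for more inhibition at the one dose given (going by the name of the read-out) and lower numbers for less inhibition), compound 2 `C=CCn1c(SCC(=O)Nc2ccc(C(C)=O)cc2)nnc1-c1ccc(OC)c(OC)c1` gives 58%, the lower of the two numbers measured so far; compound 1 `C=CCn1c(SCC(=O)Nc2ccc(/C(C)=N/O)cc2)nnc1-c1ccccc1`, which gives 73% in this assay, stands above it by a margin beyond the usual scatter. Compound 3 `C=CCn1c(SCC(=O)Nc2ccc(/C(C)=N/O)cc2)nnc1-c1ccc(OC)c(OC)c1` is compound 2 with the change (a group of 4 heavy atoms (2 carbon, 1 nitrogen, 1 oxygen; no ring) in place of a group of 3 heavy atoms (2 carbon, 1 oxygen; no ring), on an aromatic carbon). Going by the values given here, no measured pair isolates this change, since compound 1 also differs from compound 2 elsewhere on the shared core. The expected step is a number 7 percentage points higher from compound 2 to compound 3 (within the scatter), upward, though it may not clear the scatter. Compound 3 is estimated at 65%, within a range from 50% to 80%.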

Compound 3, a percentage reported as inhibition, in the whole organism at one dose (the size of the read-out at that dose, not a potency): 70%
For compound 3 the middle estimate is 5 percentage points below the measured one; low and high end bracket the measured number.
By their numbers in this assay, from the lowest: compound 2; then compounds 3 and 1 (each within the scatter of the next).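

In this assay, for the compounds shown here, the group of 4 heavy atoms in place of acetyl, on an aromatic carbon para to a large group, gives a number 12 percentage points higher from compound 2 to compound 3 (beyond the scatter), which isolates this change at this position for the first time. With that group in place, 3,4-dimethoxyphenyl in place of phenyl gives a number 3 percentage points lower from compound 1 to compound 3 (within the scatter), so this exchange leaves no step beyond the scatter. Nothing available explains either step.

On these data alone, whether an amine or a carboxylic acid at this position would match the inhibition remains open. So does whether the step from acetyl holds when phenyl replaces 3,4-dimethoxyphenyl.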